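Adding iodo to the phenyl of compound 1

This account rests on a few compounds, and the source may have more. Where it says the series, first, only, none or still open, it means among the compounds named here.

In a functional assay on HeLa cells (Homo sapiens) for antiproliferative activity, with a stated time of 48 h (a lower number here means a stronger inhibitor, a higher number a weaker inhibitor), compound 1 (`C=C(Br)C(=O)Nc1ccc(/C=C/C(=O)c2ccccc2)cc1`) gives 3900 nM and compound 2 (`C=C(Br)C(=O)Nc1ccc(/C=C/C(=O)c2ccc(Cl)c(Cl)c2)cc1`) gives 3200 nM, so the two stand level within the scatter. Compound 3 (`C=C(Br)C(=O)Nc1ccc(/C=C/C(=O)c2ccc(I)cc2)cc1`) differs from compound 1 by iodo in place of hydrogen on an aromatic carbon, para to a large group: phenyl to 4-iodophenyl. Going by the values given here, the only measured step at that phenyl, a 1.2-fold lower number from compound 1 to compound 2 (0.09 log units; within the scatter), places 3,4-dichlorophenyl there. With one such step to go on, no change beyond the scatter is expected in this assay. The estimated value for compound 3 is 3000 nM (1300 nM to 7000 nM). The expected step is a 1.3-fold lower number from compound 1 to compound 3 (0.11 log units; within the scatter).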

Compound 3, half-maximal inhibitory concentration: 7700 nM
Beside the measured number, compound 3's estimate is 2.6-fold (0.41 log units) below it; the measured number lies above the stated range.
By their numbers in this assay, from the lowest: compounds 2, 1 and 3 (each within the scatter of the next, the first and the last beyond it).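

In this assay, iodo in place of hydrogen on the aromatic carbon gives a 2.0-fold higher number from compound 1 to compound 3 (0.30 log units; within the scatter), so this change alone does not separate compound 3 from compound 1. The same phenyl does show a first readable difference between two substituted forms, with 4-iodophenyl in place of 3,4-dichlorophenyl giving a 2.4-fold higher number from compound 2 to compound 3 (0.38 log units; beyond the scatter), a modest step. No data on hand account for that difference. Still open, as far as these compounds go, is how fluoro, methoxy, an amine or a carboxylic acid at this place would read, and whether any group there moves the number clearly from that of compound 1.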